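The source may report more compounds than this note shows. Statements on the series, on what has been measured and on what is new or still open speak of the compounds shown alone.

Compound 1 `O=C(CSc1ncccn1)N/N=c1/scc(-c2ccc(Br)cc2)n1-c1ccccc1` gives > 200 ug/mL in a functional assay on C6 cells (Rattus norvegicus) for cytotoxicity, read by MTT assay, with a stated time of 24 h (a lower number here means a stronger inhibitor, a higher number a weaker inhibitor), a limit of the assay rather than a number.
Compound 2 `COc1ccc(-c2cs/c(=N/NC(=O)CSc3ncccn3)n2-c2ccccc2)cc1` gives 102 ug/mL in this assay.
Compound 3 `Cc1ccc(-c2cs/c(=N/NC(=O)CSc3ncccn3)n2-c2ccccc2)cc1` gives 85 ug/mL in this assay.

Compound 1 thus sits at the limit of > 200 ug/mL in this assay, at which 1 of the 3 values shown sits, so only a floor is known for it. Compound 4 `O=C(CSc1nnnn1-c1ccccc1)N/N=c1/scc(-c2ccc(Br)cc2)n1-c1ccccc1` differs from compound 1 in one place: 1-phenyl-1H-tetrazol-5-yl in place of pyrimidin-2-yl on a sulfur. The measured steps all concern the group on the aromatic carbon: an at least 1.9-fold lower number from compound 1 to compound 2 (0.29 log units; that floor lies within the scatter), an at least 2.3-fold lower number from compound 1 to compound 3 (0.37 log units; beyond the scatter) and a 1.2-fold lower number from compound 2 to compound 3 (0.08 log units; within the scatter). Among the compounds with values here, none of them touches the sulfur substituent, so no measured step bears on this change, and no direction can be expected beyond the scatter. Compound 4 is therefore estimated at 200 ug/mL, within 90 ug/mL to 450 ug/mL. This expectation corresponds to the step of a number no higher from compound 1 to compound 4 (the limit leaves the size open).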

Compound 4, half-maximal inhibitory concentration: 21 ug/mL
Compound 4: middle estimate off by 9.5-fold (0.98 log units), on the high side; measured number below the stated range.
By their numbers in this assay, from the lowest: compound 4; then compounds 3 and 2 (each within the scatter of the next). At a limit, above all of these: compound 1.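

Within the data shown here, changing the group on the sulfur matters in this assay, which the earlier compounds, all varied on an aromatic carbon, could not show: 1-phenyl-1H-tetrazol-5-yl in place of pyrimidin-2-yl gives an at least 9.5-fold lower number from compound 1 to compound 4 (0.97 log units; beyond the scatter). That step is only a floor, because compound 1 is held at a limit of the assay: the limit of > 200 ug/mL in this assay, at which 1 of the 4 values shown sits.

As far as these compounds go, the entering group brings both a tetrazole ring and a phenyl ring, so it remains open which of them matters, and whether a methyl on the tetrazole in place of the phenyl would keep the lower number. From the compounds shown here alone, it is also open whether this change has the same effect with methoxy or methyl in place of bromo.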